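This account rests on a few compounds, and the source may have more. Where it says the series, first, only, none or still open, it means among the compounds named here.

Three compounds have been measured in a functional assay on A549 cells (Homo sapiens) for cytotoxicity, read by MTT assay, with a stated time of 72 h; on this read-out higher numbers stand for weaker inhibition and lower numbers for stronger inhibition:

compound 1 `O=C(N/N=C/c1ccc(F)cc1)N1CCc2ncnc(Nc3ccc(F)c(Cl)c3)c2C1` gives 11400 nM
compound 2 `O=C(N/N=C/c1cccs1)N1CCc2ncnc(Nc3ccc(F)c(Cl)c3)c2C1` gives > 200000 nM, which is a limit of the assay and not a number
compound 3 `O=C(N/N=C/c1ccc(F)cc1)N1CCc2ncnc(Nc3cccc(Br)c3)c2C1` gives 2270 nM

Compound 1 and compound 2 share one core and differ only in thiophen-2-yl in place of 4-fluorophenyl on a carbon with a double bond to nitrogen; this change made an at least 17-fold higher number from compound 1 to compound 2 (1.24 log units; beyond the scatter), with compound 2 sitting at the limit of > 200000 nM in this assay, at which 1 of the 3 values shown sits. Compound 3 carries a different core, differing from compound 1 by 3-bromophenyl in place of 3-chloro-4-fluorophenyl on a nitrogen on an aromatic ring, which made a 5.0-fold lower number from compound 1 to compound 3 (0.70 log units; beyond the scatter).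

Compound 4 `O=C(N/N=C/c1cccs1)N1CCc2ncnc(Nc3cccc(Br)c3)c2C1` has not yet been measured. It differs from compound 3 by thiophen-2-yl in place of 4-fluorophenyl on a carbon with a double bond to nitrogen, and the place of the change is the same word for word as in the pair compound 1 to compound 2, so this is the same change carried onto the other core. Among the measured compounds shown here, only one example of it is known, and since the value of compound 2 is a limit, the size of that earlier step is itself only a lower bound. Compound 4 is expected to show a step of about a 26-fold higher number from compound 3 to compound 4 (1.42 log units; beyond the scatter). This expectation rests on compound 1 and compound 2, where the same change made an at least 17-fold higher number from compound 1 to compound 2 (1.24 log units; beyond the scatter). The estimate for compound 4 is 60000 nM, between 15000 nM and 250000 nM, with a fair chance that the assay reports only a limit.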

Compound 4, half-maximal inhibitory concentration: 50300 nM
Compound 4: middle estimate off by 1.2-fold (0.08 log units), on the high side, and the stated range covers the measured number.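

In this assay, thiophen-2-yl in place of 4-fluorophenyl on the carbon with a double bond to nitrogen again raised the number on the second core, with a 22-fold higher number from compound 3 to compound 4 (1.35 log units; beyond the scatter), so the step carried over in direction: the same change on two cores in this assay, an at least 17-fold higher number (1.24 log units; beyond the scatter) from compound 1 to compound 2 and a 22-fold higher number (1.35 log units; beyond the scatter) from compound 3 to compound 4; the limit leaves it open whether they differ

The exchange of 3-chloro-4-fluorophenyl for 3-bromophenyl also went the same way in the thiophen-2-yl pair, with an at least 3.9-fold lower number from compound 2 to compound 4 (0.59 log units; beyond the scatter): the same change on two cores in this assay, a 5.0-fold lower number (0.70 log units; beyond the scatter) from compound 1 to compound 3 and an at least 3.9-fold lower number (0.59 log units; beyond the scatter) from compound 2 to compound 4; the limit leaves it open whether they differ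

This shows that both changes kept their direction on these two cores, but it rests on one pair for each core and does not show that the size of either step is the same, since compound 2 stands at a limit and not at a number: the limit of > 200000 nM in this assay, at which 1 of the 4 values shown sits.

The compounds shown leave open whether the loss follows from thiophen-2-yl alone, or whether a furan ring, a pyridine ring or a cyclohexyl group in that place would behave in the same way. They also leave open whether the steps would hold with an ethynylphenyl group on the ring-bound nitrogen.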